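Oxan-4-yl amine series: replacing the trimethylpyrazole

The compounds below may be only part of what the source reports. "The series", "measured", "known", "first", "only" and "open" are said of these compounds alone.

Measured in a functional assay on BT-549 cells (Homo sapiens) for inhibition, read by sulforhodamine B assay, with a stated time of 6 days; a lower number here means a stronger inhibitor, a higher number a weaker inhibitor:
- compound 1 `CNCCNCc1cccc(-c2nc(Nc3ccccc3)c(C)c(-c3c(C)nn(C)c3C)n2)c1`: 8200 nM
- compound 2 `CNCCNCc1cccc(-c2nc(NC3CCOCC3)c(C)c(-c3c(C)nn(C)c3C)n2)c1`: > 50000 nM, a limit
- compound 3 `CNCCNCc1cccc(-c2nc(-c3c(C)noc3C)c(C)c(N3Cc4cccnc4C3)n2)c1`: 11900 nM

Compound 2 gives no number, only (the limit of > 50000 nM in this assay, at which 1 of the 3 values shown sits). Compound 4 `CNCCNCc1cccc(-c2nc(NC3CCOCC3)c(C)c(-c3ccc(O)cc3)n2)c1` has 4-hydroxyphenyl in place of 1,3,5-trimethyl-1H-pyrazol-4-yl on an aromatic carbon. Within the data shown here, the one measured step, an at least 6.0-fold higher number from compound 1 to compound 2 (0.78 log units; beyond the scatter), concerns the group on the nitrogen and not this place, so it bears on the change only indirectly. Compound 3 at 11900 nM and compound 1 at 8200 nM show the numbers reached so far in the series. The expected change in this assay is modest and towards a lower number: an at least 2.0-fold lower number from compound 2 to compound 4 (0.30 log units; that floor lies within the scatter). For compound 4 the estimate is 25000 nM, with an expected range of 9000 nM to 50000 nM.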

Compound 4, half-maximal inhibitory concentration: 23700 nM
Beside the measured number, compound 4's estimate is 1.1-fold (0.02 log units) above it; measured number inside the range.
By their numbers in this assay, from the lowest: compounds 1, 3 and 4 (each within the scatter of the next, the first and the last beyond it). At a limit, above all of these: compound 2.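

At this place, on an aromatic carbon next to the ring nitrogen, 4-hydroxyphenyl in place of 1,3,5-trimethyl-1H-pyrazol-4-yl gives an at least 2.1-fold lower number from compound 2 to compound 4 (0.32 log units; beyond the scatter) in this assay. With the oxan-4-yl amine kept, this change brings the series back to a readable number. The step is only a floor, as compound 2 stands at a limit: the limit of > 50000 nM in this assay, at which 1 of the 4 values shown sits.

Open, going by these compounds, is whether the hydroxyl matters or only the change of ring: a plain phenyl or a 4-methoxyphenyl here would separate the two. Also open, on these data alone, is whether 4-hydroxyphenyl gives a similar step with the phenyl amine of compound 1.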